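The source may report more compounds than this note shows. Statements on the series, on what has been measured and on what is new or still open speak of the compounds shown alone.

Measured so far:
compound 1 `CCCN(c1cnc(C(=O)[C@H]2C[C@@H]2C(=O)O)c(OC)c1)c1ccc(F)c2ccccc12` — 0.626 nM
compound 2 `CCN(c1cnc(C(=O)[C@H]2C[C@@H]2C(=O)O)c(OC)c1)c1ccc(F)c2ccccc12` — 1.05 nM
compound 3 `COc1cc(N(CC(C)(C)O)c2cccc(C(F)(F)F)c2)cnc1C(=O)[C@H]1C[C@@H]1C(=O)O` — 31.8 nM

In an assay for inhibition of leukotriene C4 synthase (Homo sapiens), read by LC-MS, with stated times of 15 min and 30 min (on this read-out lower numbers stand for stronger inhibition and higher numbers for weaker inhibition), compound 3 stands highest of the three numbers, with compound 2 nearest and compound 1 furthest. Compound 4 `COc1cc(N(Cc2ccc(F)cc2)c2cccc(C(F)(F)F)c2)cnc1C(=O)[C@H]1C[C@@H]1C(=O)O` differs from compound 3 by 4-fluorophenyl in place of 1-hydroxy-1-methylethyl on a saturated chain carbon bound to a nitrogen on an aromatic ring. Going by the values given here, the only measured step, a 1.7-fold higher number from compound 1 to compound 2 (0.22 log units; within the scatter), concerns the same chain on a nitrogen on an aromatic ring but is a different kind of change, and no measured pair exchanges the groups in question here. The expectation for compound 4 is therefore held loosely, with a moderate step down, a 2.1-fold lower number from compound 3 to compound 4 (0.33 log units; beyond the scatter), and a wide range. Compound 4 is estimated at 15 nM, between 3 nM and 80 nM.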

Compound 4, half-maximal inhibitory concentration: 13.5 nM
Compound 4: middle estimate off by 1.1-fold (0.05 log units), on the high side; measured number inside the range.
By their numbers in this assay, from the lowest: compounds 1 and 2 (each within the scatter of the next); then compound 4; then compound 3.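

In this assay the saturated chain carbon bound to a nitrogen on an aromatic ring takes 4-fluorophenyl in place of 1-hydroxy-1-methylethyl with a 2.4-fold lower number from compound 3 to compound 4 (0.37 log units; beyond the scatter), a modest gain. Losing the hydrogen-bond donor and acceptor of the leaving group and gaining an aromatic ring therefore costs no strength in this pair, while the earlier chain step stayed within the scatter. Nothing measured here accounts for the step. Open, going by these compounds, is how a plain benzyl or a 2-aminoethyl chain would stand at this place. Also open, on these data alone, is whether 4-fluorobenzyl would give a similar step alongside the other aromatic group on the nitrogen of compound 2.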